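This account rests on a few compounds, and the source may have more. Where it says the series, first, only, none or still open, it means among the compounds named here.

Of the compounds shown here, two of the same series have been tested in a functional assay on SK-HEP1 cells (Homo sapiens) for antiproliferative activity; on this read-out lower numbers stand for stronger inhibition of growth and higher numbers for weaker inhibition of growth. Compound 1, with the structure `O=c1c(-c2ccccc2)coc2cc(OC/C(=N/O)c3ccccc3)ccc12`, gives 6400000 nM in this assay. Compound 2, with the structure `O=c1c(-c2ccccc2)coc2cc(OC/C(=N/O)c3ccc(F)cc3)ccc12`, gives 6610000 nM. For the measured compounds named here, the single step between them, a fluoro in place of hydrogen on an aromatic carbon, reads a 1.0-fold higher number from compound 1 to compound 2 (0.01 log units; within the scatter), so the two numbers sit within the scatter of each other and neither compound can be called stronger or weaker.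

Compound 3, with the structure `COc1ccc(/C(COc2ccc3c(=O)c(-c4ccccc4)coc3c2)=N\O)cc1`, has not yet been measured. It differs from compound 2 in one place: methoxy in place of fluoro on an aromatic carbon. Going by the values given here, the only measured step that bears on this position is the one from compound 1 to compound 2, and it changed nothing beyond the scatter. On that basis a further change at the same place, methoxy in place of fluoro, is expected to leave this assay result roughly where compound 2 stands, with no step beyond the scatter in either direction, which is the expectation a 1.0-fold lower number from compound 2 to compound 3 (0.00 log units; within the scatter) expresses. Compound 3 is therefore estimated at 6600000 nM, with a range from 2500000 nM to 17000000 nM.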

Compound 3, concentration for 50% growth inhibition: 5510000 nM
The estimate for compound 3 lay 1.2-fold (0.08 log units) above the measured number; the measured number falls inside the stated range.
By their numbers in this assay, from the lowest: compounds 3, 1 and 2 (each within the scatter of the next).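

In this assay, methoxy in place of fluoro gives a 1.2-fold lower number from compound 2 to compound 3 (0.08 log units; within the scatter) and methoxy in place of hydrogen gives a 1.2-fold lower number from compound 1 to compound 3 (0.07 log units; within the scatter) at the same aromatic carbon, para to a large group. The earlier pair had covered only hydrogen and fluoro, whereas methoxy has more heavy atoms and brings a hydrogen-bond acceptor, and even so all three compounds remain within the scatter of one another, so this read-out does not separate these three groups at this position. No supporting data are available that could explain why these numbers stay together.

As far as these compounds go, it remains open whether the read-out would stay equally flat with a quite different group at this carbon, such as an amine, a carboxylic acid or a longer chain. Also open, from the compounds shown here alone, is whether a change elsewhere on the shared core, or on the oxime that all three compounds carry, would produce a step beyond the scatter in this assay in either direction.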